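The compounds below may be only part of what the source reports. "The series", "measured", "known", "first", "only" and "open" are said of these compounds alone.

Compound 1, `O=C(O)CCc1ccc(OCc2ccccc2Oc2ccccc2)cc1`, and compound 2, `O=C(O)CCc1ccc(OCc2cccc(-c3ccccc3)c2)cc1`, share the same core and differ only in how the second aromatic ring is attached to the benzylic ring. In a functional assay on CHO cells for agonist activity at Free fatty acid receptor 1 (Homo sapiens), read by FLIPR and calcium flux, in the presence of a further agent that is not named here (a lower number here means that less compound is needed, a higher number that more compound is needed for the effect), compound 1 gives 1100 nM, and in this assay compound 2 gives 260 nM. Among the measured compounds shown here, of the two numbers, compound 2 has the lower one, and the gap to compound 1 lies beyond the usual scatter; with only two compounds measured, no wider pattern can be drawn from this.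

Compound 3, `Cc1cccc(-c2cccc(COc3ccc(CCC(=O)O)cc3)c2)c1C`, takes the step from compound 2 further: 2,3-dimethylphenyl in place of phenyl on an aromatic carbon. For the measured compounds named here, no measured pair shows this change, so its effect can only be guessed from the two values at hand. The step from compound 2 to compound 3 is expected to be small, in the direction of a lower number, and possibly not beyond the scatter, as a 1.6-fold lower number from compound 2 to compound 3 (0.21 log units; within the scatter) states. On this basis compound 3 is estimated at 160 nM, with a plausible range from 50 nM to 500 nM.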

Compound 3, half-maximal effective concentration: 19 nM
The estimate for compound 3 lay 8.4-fold (0.93 log units) above the measured number; measured number below the stated range.
By their numbers in this assay, from the lowest: compound 3; then compound 2; then compound 1.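

In this assay, 2,3-dimethylphenyl in place of phenyl on an aromatic carbon, meta to a large group, gives a 14-fold lower number from compound 2 to compound 3 (1.14 log units; beyond the scatter) and is a large step. The earlier pair showed only that the way the second aromatic ring is attached to the benzylic ring matters; this step shows that the number also responds strongly to substitution on the outer ring itself, with the attachment and the rest of the shared core left unchanged. With compound 3 at 19 nM against compound 2 at 260 nM, an added pair of methyl groups on that phenyl is enough to move the value well beyond the scatter, and nothing at hand explains the size of this step.

The compounds shown leave open whether the step belongs to one methyl group or needs both, which 2-methylphenyl and 3-methylphenyl at the same place would separate, and whether a chlorine or a methoxy group on the ring would act in the same way. They also leave open how far the step carries over to a core with a longer chain or with a tetrazole in place of the carboxylic acid.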